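Phenol tosylation in a triazole-bearing series: compound 3

The compounds below may be only part of what the source reports. "The series", "measured", "known", "first", "only" and "open" are said of these compounds alone.

Measured so far:
compound 1 `C=C1C[C@]23C[C@@]1(O)CC[C@H]2c1ccc(O)c(C)c1[C@@H]3Cn1cc(-c2ccccn2)nn1` gives > 20000 nM in a functional assay on SMMC-7721 cells (Homo sapiens) for cytotoxicity, read by MTT assay, with a stated time of 4 days (on this read-out lower numbers stand for stronger inhibition and higher numbers for weaker inhibition), a limit of the assay rather than a number.
compound 2 `Cc1c(O)ccc2c1[C@H](Cn1cc(-c3ccccc3)nn1)[C@@]13CC(=O)[C@@](C)(CC[C@@H]21)C3` gives > 20000 nM in this assay, likewise a limit.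

Among the measured compounds shown here, compound 2 thus stands at the limit of > 20000 nM in this assay, at which 2 of the 2 values shown sit; no measured step separates it from compound 1. Compound 3 `Cc1ccc(S(=O)(=O)Oc2ccc3c(c2C)[C@H](Cn2cc(-c4ccccc4)nn2)[C@@]24CC(=O)[C@@](C)(CC[C@@H]32)C4)cc1` differs from compound 2 by (4-methylphenyl)sulfonyl in place of hydrogen on an oxygen on an aromatic ring, a (4-methylphenyl)sulfonyl in place of hydrogen on an oxygen on an aromatic ring. With both measured values at a limit, no step beyond the scatter is expected in this assay in either direction. Compound 3 is estimated at 25000 nM (8000 nM to 80000 nM), the expected step being a step that the limit leaves unreadable from compound 2 to compound 3.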

Compound 3, half-maximal inhibitory concentration: > 20000 nM
Compound 3: only a limit was reported; the forecaster's own chance of this, stated with the estimate: 80%; the middle value is on the limit's open side.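

In this assay compound 3 gives > 20000 nM, a limit and not a number. Among the compounds shown here, compound 2 also sits at a limit, so no step from it to compound 3 can be read. The compounds shown leave open what (4-methylphenyl)sulfonyl in place of hydrogen does to the read-out, and how compound 1, compound 2 and compound 3 rank.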